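The source may hold more compounds than are shown below. What is called first, only, known or untested is meant among the compounds shown, and "the series" means these compounds.

Compound 1, `N#CC1=C(NCN2CCCCC2)N(c2ccccc2)C(=O)N2CCCCC(N3CCCC3)C12`, gives 36.9%.
Compound 2, `N#CC1=C(/N=C/Nc2ccccc2)N(c2ccccc2)C(=O)N2CCCCC(N3CCCC3)C12`, gives 47.5%.
Compound 3, `N#CC1=C(NC(=O)c2ccccc2O)N(c2ccccc2)C(=O)N2CCCCC(N3CCCC3)C12`, gives 53.8%.

In a functional assay on the whole organism (strain albino) for inhibition, with Rattus norvegicus as the target, read by paw edema, with stated times of 1 h and 2 h, at a dose of 20 mmol/kg by the intraperitoneal route (on this read-out lower numbers stand for less inhibition and higher numbers for more inhibition at the one dose given (going by the name of the read-out)), compound 3 holds the highest of the three numbers. Its nearest neighbour is compound 2, and that gap, a number 6.3 percentage points higher from compound 2 to compound 3 (within the scatter), lies within the scatter, so no order can be read between compound 2 and compound 3. The gap to compound 1, a number 16.9 percentage points higher from compound 1 to compound 3 (beyond the scatter), lies beyond the scatter, and so does the step of a number 10.6 percentage points higher from compound 1 to compound 2 (beyond the scatter).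

Compound 4, `N#CC1=C(NCC(=O)N2CCCCC2)N(c2ccccc2)C(=O)N2CCCCC(N3CCCC3)C12`, has not yet been measured in this assay. It differs from compound 3 at the amine nitrogen whose other neighbour is a double-bonded ring carbon: ((piperidin-1-yl)carbonyl)methyl in place of (2-hydroxyphenyl)carbonyl on an amine nitrogen. The entering group carries a six-membered non-aromatic ring with one hetero atom, as does the (piperidin-1-yl)methyl group of compound 1, and the step of a number 16.9 percentage points higher from compound 1 to compound 3 (beyond the scatter) shows what happened when that sort of group gave way to the (2-hydroxyphenyl)carbonyl group. Going by the values given here, on that footing a step downward in this assay is expected for compound 4, though the entering group is not the same as the one in compound 1, so the full size of that step need not be recovered. The expected step is a number 11.8 percentage points lower from compound 3 to compound 4 (beyond the scatter). Compound 4 is therefore estimated at 42%, with a range from 30% to 55%.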

Compound 4, a percentage reported as inhibition, in the whole organism at one dose (the size of the read-out at that dose, not a potency): 46.1%
Estimate against measurement, compound 4: 4.1 percentage points below; the measured number falls inside the stated range.
By their numbers in this assay, from the lowest: compounds 1, 4, 2 and 3 (each within the scatter of the next, the first and the last beyond it).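

In this assay, putting ((piperidin-1-yl)carbonyl)methyl in place of (2-hydroxyphenyl)carbonyl on the amine nitrogen gives a number 7.7 percentage points lower from compound 3 to compound 4 (within the scatter), so at this position a group without an aromatic ring and without a hydrogen-bond donor is not separated from the (2-hydroxyphenyl)carbonyl group. The other two comparisons read the same way: a number 1.4 percentage points lower from compound 2 to compound 4 (within the scatter), and, with a carbonyl added to the (piperidin-1-yl)methyl chain, a number 9.2 percentage points higher from compound 1 to compound 4 (within the scatter). Thus compound 4 cannot be ordered against any of the other three, even though compound 1 and compound 3 stand apart beyond the scatter, and nothing measured here accounts for these numbers.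

From the compounds shown here alone, it stays open whether a longer chain in place of the methyl of ((piperidin-1-yl)carbonyl)methyl, or a morpholin-4-yl or dimethylamino group in place of the piperidin-1-yl, would shift the number beyond the scatter. Going by these compounds, what a plain phenylcarbonyl group on the same amine nitrogen would give also remains open, so the part played by the hydroxyl of the (2-hydroxyphenyl)carbonyl group cannot be told.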